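This account rests on a few compounds, and the source may have more. Where it says the series, first, only, none or still open, it means among the compounds named here.

Compound 1 `C[C@@H](O)[C@H]1C(=O)N2C(C(=O)OCOC(=O)C(C)(C)C)=C(S[C@@H]3CN[C@H](C(=O)Nc4cccc(C(=O)O)c4)C3)[C@H](C)[C@H]12` and compound 2 `C[C@@H](O)[C@H]1C(=O)N2C(C(=O)OCOC(=O)OC3CCCCC3)=C(S[C@@H]3CN[C@H](C(=O)Nc4cccc(C(=O)O)c4)C3)[C@H](C)[C@H]12` share the same core and differ only at one carbonyl carbon. In an ADME assay on a cell-free system (plasma, Homo sapiens) for metabolic stability, read by LC-MS, with a stated time of 60 min, at 37 degrees C, tested at 50 uM (on this read-out lower numbers stand for a less stable compound and higher numbers for a more stable compound), compound 1 gives 45%, and in this assay compound 2 gives 46%. Within the data shown here, compound 2 thus stands with compound 1 as its only neighbour on this read-out, and the single measured step, a number 1 percentage points higher from compound 1 to compound 2 (within the scatter), lies within the scatter, so the two compounds cannot be separated on these numbers.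

Compound 3 `CC(C)C(=O)OCOC(=O)C1=C(S[C@@H]2CN[C@H](C(=O)Nc3cccc(C(=O)O)c3)C2)[C@H](C)[C@@H]2[C@@H]([C@@H](C)O)C(=O)N12` is the unmeasured member of the set. It differs from compound 2 by isopropyl in place of cyclohexyloxy on a carbonyl carbon. Among the measured compounds shown here, the only measured step that bears on this change is the one at the same carbonyl carbon, a number 1 percentage points higher from compound 1 to compound 2 (within the scatter), which was within the scatter; there is no measured step for an isopropyl group at this position. On that basis the step of a number 1 percentage points lower from compound 2 to compound 3 (within the scatter) is expected to remain within the scatter, with no clear direction. Compound 3 is therefore estimated to give 45% in this assay, with a range from 30% to 60%.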

Compound 3, percent of the compound remaining: 15%
Estimate against measurement, compound 3: 30 percentage points above; the measured number lies below the stated range.
By their numbers in this assay, from the lowest: compound 3; then compounds 1 and 2 (each within the scatter of the next).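

At this carbonyl carbon the end group does decide the outcome in this assay: isopropyl in place of cyclohexyloxy gives a number 31 percentage points lower from compound 2 to compound 3 (beyond the scatter), and hydrogen in place of methyl on the saturated chain carbon bound to a carbonyl carbon and two saturated chain carbons gives a number 30 percentage points lower from compound 1 to compound 3 (beyond the scatter). The earlier pair, tert-butyl against cyclohexyloxy, had shown no separation, so its flat step did not mean that this position is indifferent to the group it carries; the single methyl that separates tert-butyl from isopropyl is enough to produce a step beyond the scatter. Nothing in the data available here explains this difference.

Compound 1 carries no oxygen in this group and compound 2 does, yet the two cannot be separated, so the compounds shown do not reveal which feature sets compound 3 apart from them. On these data alone, it remains open whether an isopropyloxy group, a straight propyl chain or a chain ending in an amine at this carbonyl carbon would stand with compound 3 or with compound 1 and compound 2.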